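Phenylethenyl in Place of Phenyl on the Shared Core

The compounds below may be only part of what the source reports. "The series", "measured", "known", "first", "only" and "open" are said of these compounds alone.

Compound 1 `COc1ccc(Nc2cc(C(C)C)oc(=O)c2)cc1` sets the shared core; in a functional assay on SK-BR-3 cells (Homo sapiens) for cytotoxicity, read by MTT assay, with a stated time of 72 h (on this read-out lower numbers stand for an effect already at smaller amounts and higher numbers for an effect only at larger amounts of compound), compound 1 gives > 30 uM, which is a limit of the assay and not a number. Compound 2 `COc1ccc(Nc2cc(-c3ccccc3)oc(=O)c2)cc1` gives 0.079 uM in this assay, the lowest of the two numbers shown, while compound 3 `COc1ccc(Nc2cc(-c3ccc4ccccc4c3)oc(=O)c2)cc1` gives 0.13 uM, within the scatter of compound 2. For the measured compounds named here, the one measured step in a single place is an at least 370-fold lower number from compound 1 to compound 2 (2.57 log units; beyond the scatter). Compound 4 `COc1ccc(Nc2cc(/C=C/c3ccccc3)oc(=O)c2)cc1` carries 2-phenylethenyl in place of phenyl on an aromatic carbon. Going by the values given here, no measured step replaces one aryl group by a longer one, and compounds 2 and 3 show that enlarging the aryl group changes little. The expected step is therefore a 1.3-fold higher number from compound 2 to compound 4 (0.10 log units; within the scatter), within the scatter. Compound 4 is estimated at 0.1 uM, between 0.03 uM and 0.4 uM.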

Compound 4, concentration for half-maximal effect: 0.083 uM
Compound 4: middle estimate off by 1.2-fold (0.08 log units), on the high side, within the range that was stated.
By their numbers in this assay, from the lowest: compounds 2, 4 and 3 (each within the scatter of the next). At a limit, above all of these: compound 1.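

At the position next to the ring oxygen, this assay shows that 2-phenylethenyl can take the place of phenyl with a 1.1-fold higher number from compound 2 to compound 4 (0.02 log units; within the scatter). Set against isopropyl, the same group gives an at least 360-fold lower number from compound 1 to compound 4 (2.55 log units; beyond the scatter), so the large step seen with phenyl is also reached with a group that carries a double bond outside the aromatic ring. Compound 1 stands at a limit of the assay, not at a number: the limit of > 30 uM in this assay, at which 1 of the 4 values shown sits.

On these data alone, what a 2-phenylethyl chain or a cyclohexyl group would give at this position stays open. So does the effect of a pyridine ring in place of the carbon-only aromatic ring.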